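This account rests on a few compounds, and the source may have more. Where it says the series, first, only, none or still open, it means among the compounds named here.

The shared core of compound 1 `O=C(C/C=C/c1cccc(Cl)c1)Nc1nc2ccccc2c(=O)s1` carries an amide-linked side chain ending in a chloro-substituted aromatic ring. In an assay on CHO cells for displacement of a labelled ligand from adenosine receptor A2b (Homo sapiens), read by scintillation counting, with a stated time of 75 min (a lower number here means a stronger inhibitor, a higher number a weaker inhibitor), compound 1 reaches only the limit > 1000 nM, so no number is known for it. Compound 2 `O=C(C/C=C/c1ccc(Cl)c(Cl)c1)Nc1nc2ccccc2c(=O)s1` also stops at the limit, giving > 1000 nM in this assay. The step that the two limits leave unreadable from compound 1 to compound 2 therefore cannot be sized, and two of the three results sit at the limit (the limit of > 1000 nM in this assay, at which 2 of the 3 values shown sit). For the measured compounds named here, the only number in the set belongs to compound 3 `COc1cccc(CCC(=O)Nc2nc3ccccc3c(=O)s2)c1`, which in this assay gives 225 nM.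

Compound 4 `O=C(CCc1ccc(Cl)c(Cl)c1)Nc1nc2ccccc2c(=O)s1` differs from compound 3 by 3,4-dichlorophenyl in place of 3-methoxyphenyl on a saturated chain carbon, two bonds along the chain from a carbonyl carbon. Going by the values given here, no measured step reports this exchange directly. Among the compounds with values here, compound 2 already carries a 3,4-dichlorophenyl and gives only a limit, and compound 1 with a single chloro likewise gives only a limit, while compound 3 with the 3-methoxyphenyl is the one compound that yields a number. He therefore expects the exchange to weaken binding, with the step of a 4.0-fold higher number from compound 3 to compound 4 (0.60 log units; beyond the scatter) estimated to run toward the limit, and there is a fair chance that compound 4 itself returns only a limit. His estimate for compound 4 in this assay is 900 nM, within a range from 300 nM to 3000 nM.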

Compound 4, inhibition constant: > 1000 nM
Compound 4 was reported as a limit; the forecaster's own chance of this, stated with the estimate: 45%; middle value at least 1.1-fold (0.04 log units) from the limit.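

In this assay, for the compounds shown here, the exchange of 3-methoxyphenyl for 3,4-dichlorophenyl on a saturated chain carbon, two bonds along the chain from a carbonyl carbon, gives the first readable step in this set, an at least 4.4-fold higher number from compound 3 to compound 4 (0.64 log units; beyond the scatter), and it lies beyond the scatter. The value of compound 4 is a limit and not a number, so this step fixes only a smallest size and leaves the true distance open. Where the earlier compounds showed the 3,4-dichlorophenyl only on the unsaturated chain of compound 2, it now also fails to give a number on the saturated chain, and compound 3 remains the only compound with a measured number: the limit of > 1000 nM in this assay, at which 3 of the 4 values shown sit.

The compounds shown do not separate loss of the methoxy group from gain of the two chloro groups, so it remains open whether an unsubstituted phenyl or a phenyl with a single chloro on this saturated chain would keep a number like that of compound 3. On these data alone, how a carboxylic acid, an amine or a longer chain at this position would fare also remains open.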